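Removing a Methyl Group from a Selenium-Linked Quinoline Ester

The compounds below may be only part of what the source reports. "The series", "measured", "known", "first", "only" and "open" are said of these compounds alone.

Measured so far:
- Compound 1, `CCOC(=O)c1cc([Se]c2ccccc2C)c2cc(OC)ccc2n1`: 14900 nM
- Compound 2, `CCOC(=O)c1cc([Se]Cc2ccccc2)c2cc(Cl)ccc2n1`: 88500 nM
- Compound 3, `CCOC(=O)c1cc([Se]c2ccc3ccccc3c2)c2cc(OC)ccc2n1`: 50700 nM

In a functional assay on Jurkat cells (Homo sapiens) for cytotoxicity, read by MTT assay, with a stated time of 24 h (a lower number here means that less compound is needed, a higher number that more compound is needed for the effect), compound 1 gives 14900 nM, the lowest of the three numbers. The next nearest is compound 3 with 50700 nM, and compound 2 lies furthest away with 88500 nM; both gaps are beyond the scatter of this assay, so compound 1 needs the least material for the effect among these three.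

The compound to be measured is compound 4, `CCOC(=O)c1cc([Se]c2ccccc2)c2cc(OC)ccc2n1`. It differs from compound 1 in one place: hydrogen in place of methyl on an aromatic carbon. Put another way, the 2-methylphenyl attached to selenium becomes a plain phenyl.

Going by the values given here, no pair of measured compounds differs in just one place, so there is no directly comparable step to lean on. The change is small, a single carbon leaving an aromatic ring. The step of a 1.3-fold higher number from compound 1 to compound 4 (0.13 log units; within the scatter) is expected to be modest and to fall within or only slightly beyond the scatter, with a slight lean toward a higher number. Compound 4 is therefore estimated at 20000 nM, with a likely range from 8000 nM to 50000 nM.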

Compound 4, half-maximal effective concentration: 102000 nM
Beside the measured number, compound 4's estimate is 5.1-fold (0.71 log units) below it; the measured number lies above the stated range.
By their numbers in this assay, from the lowest: compound 1; then compounds 3, 2 and 4 (each within the scatter of the next).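

In this assay the step is a 6.8-fold higher number from compound 1 to compound 4 (0.84 log units; beyond the scatter) and it lies well beyond the scatter, so this place on the ring attached to selenium is not indifferent to a small change. Losing a single carbon, ortho to a large group, separates the 2-methylphenyl of compound 1 clearly from the plain phenyl of compound 4, something the earlier compounds, which differ in more than one place, could not show. Nothing available here explains why one methyl group counts for so much.

The compounds shown leave open whether an ethyl group or a chlorine atom in this same place would keep the lower number, or whether only methyl does. They also leave open whether the methyl would count for as much with chlorine instead of methoxy on the core.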